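A few compounds are considered here, and "the series" means these few. Any claim that something is new, unique, unknown or untested is made for them only; others in the source may bear on it.

In a functional assay on UACC-62 cells (Homo sapiens) (a higher number here means a weaker inhibitor of growth, a lower number a stronger inhibitor of growth), three compounds that differ only in one group on an aromatic carbon have been measured. Compound 1 `O=S(=O)(/C=C/c1ccc(F)cc1)Cc1ccc(Nc2ncnc3ccccc23)cc1`, which carries fluoro, gives 5000 nM. Compound 3 `O=S(=O)(/C=C/c1ccc(Cl)cc1)Cc1ccc(Nc2ncnc3ccccc23)cc1`, which carries chloro, gives 13000 nM. Compound 2 `O=S(=O)(/C=C/c1ccc(Br)cc1)Cc1ccc(Nc2ncnc3ccccc23)cc1`, which carries bromo, is recorded only as a limit of the assay, > 100000 nM. For the measured compounds named here, compound 3 therefore has the higher of the two actual numbers, and the only other value is that limit.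

Compound 4 `O=S(=O)(/C=C/c1ccc(O)cc1)Cc1ccc(Nc2ncnc3ccccc23)cc1` has not yet been measured. It differs from compound 3 by hydroxy in place of chloro on an aromatic carbon, para to a large group. Going by the values given here, no measured step involves hydroxy, so the only guide is the swaps among fluoro, chloro and bromo at this same place. The modest step is a 2.6-fold higher number from compound 1 to compound 3 (0.41 log units; beyond the scatter). A step of at least modest size is an at least 7.6-fold lower number from compound 2 to compound 3 (0.88 log units; beyond the scatter), and the large one is an at least 20-fold higher number from compound 1 to compound 2 (1.30 log units; beyond the scatter). These steps show that the number responds to this group, but they do not fix a direction for hydroxy. Only a small shift toward stronger growth inhibition is therefore expected, and it may not rise beyond the scatter, with wide uncertainty on both sides. The expected change is a 1.3-fold lower number from compound 3 to compound 4 (0.11 log units; within the scatter). For compound 4 the estimated value is 10000 nM, with an expected range from 2500 nM to 40000 nM.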

Compound 4, concentration for 50% growth inhibition: 100000 nM
Estimate against measurement, compound 4: 10-fold (1.00 log units) below; the measured number lies above the stated range.
By their numbers in this assay, from the lowest: compound 1; then compound 3; then compound 4.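

In this assay, hydroxy on this aromatic carbon, para to a large group, gives a clearly weaker result than the halogens that have actual numbers: a 7.7-fold higher number from compound 3 to compound 4 (0.89 log units; beyond the scatter), and a 20-fold higher number from compound 1 to compound 4 (1.30 log units; beyond the scatter). The earlier compounds shown here showed the number responding only to swaps among fluoro, chloro and bromo, whereas this change, which brings in one hydrogen-bond donor and one hydrogen-bond acceptor, shows that a non-halogen group can also shift it strongly toward weaker growth inhibition, and compound 1, with fluoro, keeps the lowest number of the four. Compound 2 is recorded only as a limit, so the size of its step cannot be read (a number no higher from compound 2 to compound 4 (the limit leaves the size open)): the limit of > 100000 nM in this assay, at which 1 of the 4 values shown sits.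

As far as these compounds go, it remains open how a methoxy group, an amine or a carboxylic acid at this same place would read, and whether any of them would come closer to fluoro or to hydroxy. The compounds also offer no measurement that explains the order among these groups, so the result describes this series at this one position and gives no reason for it.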